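The source may report more compounds than this note shows. Statements on the series, on what has been measured and on what is new or still open speak of the compounds shown alone.

Measured compounds in a functional assay on MCF7 cells (Homo sapiens) for antiproliferative activity; on this read-out higher numbers stand for weaker inhibition and lower numbers for stronger inhibition:

Compound 1, `C#CCCCn1c(Cc2cc(OC)c(OC)c(OC)c2)nc2c(N)ncnc21`, gives 24000 nM.
Compound 2, `CCCCCn1c(Cc2cc(OC)c(OC)c(OC)c2)nc2c(N)nc(F)nc21`, gives 36300 nM.
Compound 3, `CC#CCCn1c(Cc2cc(OC)c(OC)c(OC)c2)nc2c(N)nc(F)nc21`, gives 37200 nM.

All three compounds share one core and differ only in the chain on the aromatic nitrogen and in one substituent on the core. The number for compound 1 lies within the usual scatter of the numbers for compound 2 and compound 3, so the three cannot be told apart on this read-out.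

Compound 4, `CCC(C)Cn1c(Cc2cc(OC)c(OC)c(OC)c2)nc2c(N)ncnc21`, has not yet been measured. It differs from compound 1 by sec-butyl in place of but-3-yn-1-yl on a saturated chain carbon bound to an aromatic nitrogen. Going by the values given here, the only measured step that touches a similar change is a 1.0-fold higher number from compound 2 to compound 3 (0.01 log units; within the scatter), which swapped a saturated chain for one with a triple bond two bonds along the chain from the aromatic nitrogen and left the number unchanged beyond the scatter. Among the compounds with values here, no measured pair covers a branched saturated chain in place of a chain with a triple bond. Given that, compound 4 is expected to sit close to compound 1, with a step of a 1.0-fold higher number from compound 1 to compound 4 (0.02 log units; within the scatter), that is, no change beyond the scatter. The estimate for compound 4 is therefore 25000 nM, with a range from 10000 nM to 60000 nM.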

Compound 4, half-maximal inhibitory concentration: 61700 nM
For compound 4 the middle estimate is 2.5-fold (0.39 log units) below the measured one, outside the stated range (above it).
By their numbers in this assay, from the lowest: compounds 1, 2, 3 and 4 (each within the scatter of the next, the first and the last beyond it).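

In this assay, sec-butyl in place of but-3-yn-1-yl gives a 2.6-fold higher number from compound 1 to compound 4 (0.41 log units; beyond the scatter), so inhibition is modestly weaker. Going by these compounds alone, this is the first step at this chain position to go beyond the scatter, which shows that the number can respond to the chain's shape even when the carbon count stays the same and no ring, hydrogen-bond donor or acceptor, or net charge is involved. Nothing available explains why this step occurs.

Compound 4 both loses the triple bond and gains a branch, so the compounds shown do not reveal which of the two changes matters, and a straight butyl chain on the core of compound 1 would help separate them. As far as these compounds go, it also remains open how a longer chain or a chain ending in an amine would behave at this position.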